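Swapping the Aryl Group on a Hydrazone Tail

The compounds below may be only part of what the source reports. "The series", "measured", "known", "first", "only" and "open" are said of these compounds alone.

Compound 1 `CN(C)CCn1cnnc1-c1cc(Oc2ccc(NC(=O)N/N=C/c3ccc(O)c(Br)c3)cc2F)ccn1`: 12400 nM
Compound 2 `CN(C)CCn1cnnc1-c1cc(Oc2ccc(NC(=O)N/N=C/c3ccc(O)cc3)cc2F)ccn1`: 7750 nM
Compound 3 `CN(C)CCn1cnnc1-c1cc(Oc2ccc(NC(=O)N/N=C/c3ccc(F)cc3Cl)cc2F)ccn1`: 1210 nM

The three measured compounds share one core and differ only in the aromatic ring held on the carbon with a double bond to nitrogen. In a functional assay on U-87MG ATCC cells (Homo sapiens) for cytotoxicity, read by MTT assay, with a stated time of 72 h (a lower number here means a stronger inhibitor, a higher number a weaker inhibitor), compound 1 gives 12400 nM, the highest of the three numbers. Its nearest neighbour is compound 2 a 1.6-fold lower number from compound 1 to compound 2 (0.20 log units; within the scatter), while compound 3 is furthest a 10-fold lower number from compound 1 to compound 3 (1.01 log units; beyond the scatter); compound 2 to compound 3 shows a comparable shift a 6.4-fold lower number from compound 2 to compound 3 (0.81 log units; beyond the scatter).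

Compound 4 `CN(C)CCn1cnnc1-c1cc(Oc2ccc(NC(=O)N/N=C/c3ccc(O)cc3O)cc2F)ccn1` has not yet been measured. It differs from compound 1 as follows: 2,4-dihydroxyphenyl in place of 3-bromo-4-hydroxyphenyl on a carbon with a double bond to nitrogen. The hydroxyl-bearing ring is kept, so the step from compound 1 to compound 2, which was within the scatter, is the closest guide; the larger steps to compound 3 involve a ring without any hydroxyl and bear less directly. A small change or none beyond the scatter is therefore expected, a 1.6-fold lower number from compound 1 to compound 4 (0.19 log units; within the scatter). Compound 4 is estimated at 8000 nM, with a range from 3000 nM to 20000 nM.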

Compound 4, half-maximal inhibitory concentration: 15400 nM
Beside the measured number, compound 4's estimate is 1.9-fold (0.28 log units) below it; the measured number falls inside the stated range.
By their numbers in this assay, from the lowest: compound 3; then compounds 2, 1 and 4 (each within the scatter of the next).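

In this assay, adding a second hydroxy to the ring of compound 2 stays within the scatter (a 2.0-fold higher number from compound 2 to compound 4 (0.30 log units; within the scatter)), and so does the full ring swap from compound 1 (a 1.2-fold higher number from compound 1 to compound 4 (0.09 log units; within the scatter)). Compounds 1, 2 and 4 therefore cannot be told apart, even though their rings carry a bromo, a single hydroxy or two hydroxy groups. The ring without any hydroxy stands clearly apart from the new compound (a 13-fold higher number from compound 3 to compound 4 (1.10 log units; beyond the scatter)), so the gap seen earlier also holds for 2,4-dihydroxyphenyl.

On these data alone, it remains open whether the chloro or the fluoro of compound 3 matters more, and what a ring bearing an amine or a carboxylic acid would give. Nothing measured here offers a reason for the gap between compound 3 and the hydroxy-bearing compounds.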